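From sulfur with one oxygen to methylsulfonyl

A few compounds are considered here, and "the series" means these few. Any claim that something is new, unique, unknown or untested is made for them only; others in the source may bear on it.

Measured in a functional assay on the whole organism for antagonist activity, with Mus musculus as the target; on this read-out lower numbers stand for an effect already at smaller amounts and higher numbers for an effect only at larger amounts of compound:
- compound 1 `Cn1c(-c2cccc(F)c2)nnc1S(C)(=O)=O` gives 12.1 mg/kg
- compound 2 `CSc1n[nH]c(-c2ccc(F)cc2)n1` gives > 200 mg/kg
- compound 3 `Cn1c(-c2ccccc2)nnc1[S+](C)[O-]` gives 18.6 mg/kg

The entry for compound 2 is a limit of the assay and not a number. The numbers for compound 3 and compound 1 lie within the usual scatter of each other. Compound 4 `Cn1c(-c2ccccc2)nnc1S(C)(=O)=O` keeps the core of compound 3 and changes one group, on an aromatic carbon between two ring nitrogen atoms (a group of 4 heavy atoms (1 carbon, 2 oxygen, 1 sulfur; no ring) in place of a group of 3 heavy atoms (1 carbon, 1 oxygen, 1 sulfur; no ring), on an aromatic carbon). Within the data shown here, no measured pair isolates this change. Compound 1 also carries methylsulfonyl and gives 12.1 mg/kg, so in this assay no change beyond the scatter is expected, with the estimated step being a 1.2-fold lower number from compound 3 to compound 4 (0.09 log units; within the scatter). The estimate for compound 4 is 15 mg/kg, with an expected range from 7 mg/kg to 32 mg/kg.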

Compound 4, dose for half-maximal effect: 12.8 mg/kg
For compound 4 the middle estimate is 1.2-fold (0.07 log units) above the measured one; measured number inside the range.
By their numbers in this assay, from the lowest: compounds 1, 4 and 3 (each within the scatter of the next). At a limit, above all of these: compound 2.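

Swapping the group with one oxygen on sulfur for methylsulfonyl, now compared directly on one core, gives no change beyond the scatter in this assay: the step is a 1.5-fold lower number from compound 3 to compound 4 (0.16 log units; within the scatter). So on this aromatic carbon, the two sulfur groups cannot be told apart by this read-out. The comparison also isolates hydrogen in place of fluoro on an aromatic carbon, and that step is also within the scatter: a 1.1-fold higher number from compound 1 to compound 4 (0.02 log units; within the scatter).

Still open, going by these compounds, is how an amine or a carboxylic acid on this aromatic carbon would read in this assay. Nothing given here offers a reason for these two results.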